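Solubility across five-membered ring variants on a salicylate core

A few compounds are considered here, and "the series" means these few. Any claim that something is new, unique, unknown or untested is made for them only; others in the source may bear on it.

Three compounds share one core and differ only in the five-membered ring on it. Compound 1 `O=C(O)c1cc(-n2ccnc2)ccc1O` gives 2000 ug/mL in a physicochemical assay for solubility, in phosphate buffer, at pH 7; a lower number here means a less soluble compound, a higher number a more soluble compound; compound 2 `O=C(O)c1cc(-c2ncccn2)ccc1O` gives 6000 ug/mL; compound 3 `O=C(O)c1cc(-c2cscn2)ccc1O` gives 2700 ug/mL, the second highest of the three numbers, nearest compound 1 and furthest from compound 2. Within the data shown here, the one measured step, a 1.4-fold higher number from compound 1 to compound 3 (0.13 log units; within the scatter), lay within the scatter. Compound 4 `O=C(O)c1cc(C2N=NN=N2)ccc1O` is not yet measured; the change is a group of 5 heavy atoms (1 carbon, 4 nitrogen; one five-membered non-aromatic ring with 4 hetero atoms) in place of a group of 5 heavy atoms (3 carbon, 1 nitrogen, 1 sulfur; one five-membered aromatic ring with 2 hetero atoms), on an aromatic carbon. Among the measured compounds shown here, no measured step exchanges an aromatic five-membered ring for a non-aromatic one with four hetero atoms, so the only guide is the narrow spread of the three values. Compound 4 is expected near the middle of that spread, with an estimated step of a 1.3-fold higher number from compound 3 to compound 4 (0.11 log units; within the scatter); the estimate for compound 4 is 3500 ug/mL with a range from 1500 ug/mL to 9000 ug/mL.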

Compound 4, solubility: 1700 ug/mL
Compound 4: middle estimate off by 2.1-fold (0.31 log units), on the high side, within the range that was stated.
By their numbers in this assay, from the lowest: compounds 4, 1 and 3 (each within the scatter of the next); then compound 2.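

In this assay the non-aromatic five-membered ring with 4 hetero atoms, on this aromatic carbon, gives a 1.6-fold lower number from compound 3 to compound 4 (0.20 log units; within the scatter) and a 1.2-fold lower number from compound 1 to compound 4 (0.07 log units; within the scatter) and both steps lie within the scatter. At this position, exchanging either five-membered aromatic ring for this non-aromatic ring therefore produces no difference that can be read. No measurement shown here bears on this result.

As far as these compounds go, whether an amine or a carboxylic acid in place of the five-membered ring would produce a step beyond the scatter remains open. Also open, from the compounds shown here alone, is whether the same exchange would behave alike without the hydroxy group on the shared core.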